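From carboxy to butoxycarbonyl on the shared core

The source may report more compounds than this note shows. Statements on the series, on what has been measured and on what is new or still open speak of the compounds shown alone.

Compound 1 `O=C(O)c1cnc(Oc2ccc3c(c2)B(O)OC3)cn1`: > 100000 nM
Compound 2 `NC(=O)c1cnc(Oc2ccc3c(c2)B(O)OC3)cn1`: 48200 nM
Compound 3 `CCCCOC(=O)c1cnc(Oc2ccc3c(c2)B(O)OC3)cn1`: not yet measured

In an ADME assay on Jurkat cells (Homo sapiens) for cytotoxicity, read by MTT assay, with a stated time of 72 h (a lower number here means a stronger inhibitor, a higher number a weaker inhibitor), compound 1 gives > 100000 nM, which is a limit of the assay and not a number. Compound 3 keeps the core of compound 1 and changes carboxy to butoxycarbonyl: butyl in place of hydrogen on an oxygen next to a carbonyl group. Among the compounds with values here, one measured step bears on this change, an at least 2.0-fold lower number from compound 1 to compound 2 (0.31 log units; beyond the scatter), with amino in place of hydroxy on a carbonyl carbon. That step starts from a limit, so its true size is open, and it involves a different group from butoxy. It therefore supports an expectation of direction more than of size: a lower number, beyond the scatter and of moderate size. The expected change is an at least 4.0-fold lower number from compound 1 to compound 3 (0.60 log units; beyond the scatter). For compound 3 the estimate is 25000 nM, with an expected range of 6000 nM to 90000 nM.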

Compound 3, half-maximal inhibitory concentration: > 100000 nM
Compound 3 gave a limit, no number (the forecaster's own chance of this, stated with the estimate: 15%); middle value at least 4.0-fold (0.60 log units) away from the limit.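

Replacing amino with butoxy on the carbonyl carbon gives an at least 2.0-fold higher number from compound 2 to compound 3 (0.31 log units; beyond the scatter) in this assay, so the lower number seen with amino does not carry over to butoxy. Among the three groups shown on this carbonyl carbon, only the amino group of compound 2 gives a measured number. The step from compound 1 to compound 3 cannot be read, as both values are limits and not numbers: the limit of > 100000 nM in this assay, at which 2 of the 3 values shown sit.

From the compounds shown here alone, how far compound 1 and compound 3 lie past that limit stays open, and with it any order between carboxy and butoxycarbonyl. Also open, going by these compounds, is whether a methyl ester, a shorter chain than butyl, or a methylamide on the same carbonyl carbon would give a number near that of compound 2 or reach the limit.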